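This account rests on a few compounds, and the source may have more. Where it says the series, first, only, none or still open, it means among the compounds named here.

Of the compounds shown here, three with a shared core have been measured in a functional assay on the whole organism with Mus musculus as the target; on this read-out higher numbers stand for an effect only at larger amounts of compound and lower numbers for an effect already at smaller amounts. Compound 1 `C[C@@H](NCc1ccc(OCc2ccccc2)cc1)C(N)=O` gives 23.8 mg/kg and compound 2 `C[C@@H](NCc1ccc(OCCc2ccccc2)cc1)C(N)=O` gives 24.9 mg/kg, and a 1.0-fold higher number from compound 1 to compound 2 (0.02 log units; within the scatter) shows that benzyl in place of phenyl left the number unchanged within the scatter. Compound 3 `C[C@@H](NCc1ccc(OCc2ccccn2)cc1)C(N)=O` stands highest of the three at 172 mg/kg, so it needs the largest dose. It is separated from the other two by a 7.2-fold higher number from compound 1 to compound 3 (0.86 log units; beyond the scatter) and a 6.9-fold higher number from compound 2 to compound 3 (0.84 log units; beyond the scatter).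

Compound 4 `C[C@@H](NCc1ccc(OCc2cccs2)cc1)C(N)=O` differs from compound 3 in one place: thiophen-2-yl in place of pyridin-2-yl on a saturated chain carbon bound to an oxygen on an aromatic ring. In words, it has thiophen-2-yl in place of pyridin-2-yl on a saturated chain carbon bound to an oxygen on an aromatic ring. Among the compounds with values here, no measured step introduces thiophen-2-yl, so the evidence is indirect. Within the data shown here, the only steps that bear on the change are the two that introduced pyridin-2-yl, a 7.2-fold higher number from compound 1 to compound 3 (0.86 log units; beyond the scatter) and a 6.9-fold higher number from compound 2 to compound 3 (0.84 log units; beyond the scatter), both modest in size. Removing that group is therefore expected to reverse most, though perhaps not all, of those steps. The expected shift is a 4.5-fold lower number from compound 3 to compound 4 (0.66 log units; beyond the scatter). For compound 4 the estimated value is 38 mg/kg, with an expected range from 15 mg/kg to 100 mg/kg.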

Compound 4, dose for half-maximal effect: 61.6 mg/kg
The estimate for compound 4 lay 1.6-fold (0.21 log units) below the measured number, within the range that was stated.
By their numbers in this assay, from the lowest: compounds 1 and 2 (each within the scatter of the next); then compound 4; then compound 3.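

In this assay the place on a saturated chain carbon bound to an oxygen on an aromatic ring now separates the aromatic rings in finer steps: a 2.8-fold lower number from compound 3 to compound 4 (0.45 log units; beyond the scatter) shows that thiophen-2-yl recovers part of what pyridin-2-yl gave up. It does not recover all of it, as a 2.6-fold higher number from compound 1 to compound 4 (0.41 log units; beyond the scatter) and a 2.5-fold higher number from compound 2 to compound 4 (0.39 log units; beyond the scatter) leave the thiophen-2-yl compound short of both the phenyl and the benzyl compound. The higher number is therefore not confined to pyridin-2-yl, for both rings with a hetero atom stand above phenyl here, by steps of different size, and neither of the two goes against this. Nothing shown here explains why the two rings differ.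

The compounds shown leave open where a furan-2-yl or pyridin-3-yl ring on the same carbon would fall, and whether pyridin-2-yl or thiophen-2-yl on a longer chain would behave as benzyl did against phenyl. They also leave open what an amine or a carboxylic acid would do in place of the ring at this place.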